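The source may report more compounds than this note shows. Statements on the series, on what has been measured and on what is new or still open speak of the compounds shown alone.

Compound 1 `OC(c1ccc(Cl)cc1)(c1cncnc1)c1cccc(F)c1`: in an ADME assay on L6 cells (Rattus norvegicus) for cytotoxicity, read by resazurin assay, with a stated time of 72 h (a lower number here means a stronger inhibitor, a higher number a weaker inhibitor), compound 1 gives > 100000 nM, which is a limit of the assay and not a number.
Compound 2 `OC(c1ccc(Cl)cc1)(c1cccnc1)c1cccc(F)c1`: in this assay compound 2 gives 66000 nM.

Compound 2 carries the only number shown in this assay; the further value, that of compound 1, is a limit. Among the compounds with values here, the one measured step, an at least 1.5-fold lower number from compound 1 to compound 2 (0.18 log units; that floor lies within the scatter), has its floor within the scatter, so it shows no real change, and the floor rests on (the limit of > 100000 nM in this assay, at which 1 of the 2 values shown sits).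

Compound 3 `OC(c1ccc(Cl)cc1)(c1cccnc1)c1nccs1` differs from compound 2 by 1,3-thiazol-2-yl in place of 3-fluorophenyl on a saturated chain carbon bound to two aromatic carbons and an oxygen on a saturated carbon. Within the data shown here, no measured step touches this position or this kind of exchange; the single step known, from compound 1 to compound 2, concerns a different aromatic group on the same saturated carbon and was itself within the scatter. Nothing shown therefore supports a step beyond the scatter in this assay for compound 3, in either direction. The step expected from compound 2 to compound 3 is no change at the digits printed from compound 2 to compound 3 (within the scatter). Compound 3 is estimated at 66000 nM in this assay, within 28000 nM to 130000 nM, with a real chance that only a limit is returned.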

Compound 3, half-maximal inhibitory concentration: > 100000 nM
Compound 3: only a limit was reported (the forecaster's own chance of this, stated with the estimate: 35%); middle value at least 1.5-fold (0.18 log units) from the limit.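

In this assay, 1,3-thiazol-2-yl in place of 3-fluorophenyl on a saturated chain carbon bound to two aromatic carbons and an oxygen on a saturated carbon gives an at least 1.5-fold higher number from compound 2 to compound 3 (0.18 log units; that floor lies within the scatter). Within the data shown here, this is the first reading at this position, and its floor shows no real change, although the true step may be larger.

Compound 3 gives > 100000 nM, which is a limit of the assay and not a number.

The exchange of one six-membered aromatic ring of carbon only for one five-membered aromatic ring with 2 hetero atoms therefore yields no number here, and the size of the step cannot be read beyond its floor: the limit of > 100000 nM in this assay, at which 2 of the 3 values shown sit.

The compounds shown leave open how far the number for compound 3 lies from that of compound 2, and so whether this exchange has any real effect in this assay. They also leave open whether another group on the same saturated carbon, such as an aminomethyl group or a carboxylic acid, would move the number beyond the scatter from compound 2 in either direction.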